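The source may hold more compounds than are shown below. What is called first, only, known or untested is meant among the compounds shown, and "the series" means these compounds.

Measured so far:
compound 1 `COc1ccc(-c2cc3[nH]nc(N)c3c(=O)[nH]2)cc1`: 7%
compound 2 `Cn1nc(N)c2c(=O)[nH]c(-c3ccccc3)cc21`: 8%
compound 3 `Cn1nc(N)c2c(=O)[nH]c(-c3ccccn3)cc21`: 9%

All three were tested in an assay on isolated protein for inhibition of ribosomal protein S6 kinase alpha-1 (Homo sapiens), read by mobility shift assay, tested at 30 uM; a lower number here means less inhibition, a higher number more inhibition at the concentration tested (going by the name of the read-out). Compound 2 stands among the other two: its value lies within the scatter of compound 1 and likewise within the scatter of compound 3, so none of the three can be set apart from another on these numbers.

Compound 4 `COc1ccc(-c2cc3c(c(N)nn3C)c(=O)[nH]2)cc1` is compound 2 with a single change: methoxy in place of hydrogen on an aromatic carbon. For the measured compounds named here, the only recorded step that alters the same ring is a number 1 percentage points higher from compound 2 to compound 3 (within the scatter), where the whole ring was exchanged; it does not involve a methoxy group, but it shows that changing this part of compound 2 left the read-out essentially where it was. Going by the values given here, compound 1 already carries a methoxy group and gives a value in the same low region as compound 2, though the two differ in more than one place, so no step is drawn between them. Nothing here points to a shift in this assay beyond the scatter, so no change at the digits printed from compound 2 to compound 4 (within the scatter) is expected to be flat. Compound 4 is estimated at 8%, with a range from 0% to 20%.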

Compound 4, a percentage reported as inhibition, at one concentration (the size of the read-out at that concentration, not a potency): 18%
Estimate against measurement, compound 4: 10 percentage points below; the range from low to high includes it.
By their numbers in this assay, from the lowest: compounds 1, 2, 3 and 4 (each within the scatter of the next, the first and the last beyond it).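

In this assay the methoxy group on the carbon-only aromatic ring, para to a large group, gives a number 10 percentage points higher from compound 2 to compound 4 (within the scatter), so this change alone cannot be separated from the usual spread of repeat measurements. For the compounds shown here, the earlier compounds showed no difference that could be read, whereas methyl on the aromatic nitrogen, with methoxy present in both compounds, gives a number 11 percentage points higher from compound 1 to compound 4 (beyond the scatter), the first step here to clear that spread, though only modestly. No measurement available here explains either step.

As far as these compounds go, it remains open whether methyl on the aromatic nitrogen would produce a similar step without the methoxy group. From the compounds shown here alone, it is also open whether an amine, a carboxylic acid or a longer chain such as ethoxy, placed where methoxy sits, would shift the read-out more clearly.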